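A few compounds are considered here, and "the series" means these few. Any claim that something is new, unique, unknown or untested is made for them only; others in the source may bear on it.

Measured so far:
- compound 1 `Cn1ncc2c(=O)n(-c3ccccc3)c(SC(C)(C)c3ccccc3)nc21` — in an assay on isolated protein for inhibition of Retinaldehyde dehydrogenase 3 (Homo sapiens) (a higher number here means a weaker inhibitor, a lower number a stronger inhibitor), compound 1 gives 1390 nM
- compound 2 `CC(Sc1nc2nn(CC3COC3)cc2c(=O)n1-c1ccccc1)c1ccccc1` — in this assay compound 2 gives 60 nM
- compound 3 `C[C@@H](Sc1nc2c(cnn2C)c(=O)n1-c1ccccc1)c1ccccc1` — in this assay compound 3 gives 34 nM

Compound 3 holds the lowest number of the three; its gap to compound 2 is within the scatter, while the step of a 41-fold lower number from compound 1 to compound 3 (1.61 log units; beyond the scatter) is large and beyond it. Compound 4 `CC(Sc1nc2c(cnn2C)c(=O)n1-c1ccccc1)c1ccccn1` differs from compound 3 only by 1-(pyridin-2-yl)ethyl in place of 1-phenylethyl on a sulfur. Going by the values given here, the one measured step on this sulfur, a 41-fold lower number from compound 1 to compound 3 (1.61 log units; beyond the scatter), changed the branching of the group rather than the ring, so no measured pair speaks directly to swapping the ring. Among the compounds with values here, with no precedent for that swap, compound 4 is expected to stay near compound 3, giving an estimated step of a 1.5-fold higher number from compound 3 to compound 4 (0.17 log units; within the scatter); the estimate for compound 4 is 50 nM, with a range from 15 nM to 170 nM.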

Compound 4, half-maximal inhibitory concentration: 89 nM
For compound 4 the middle estimate is 1.8-fold (0.25 log units) below the measured one; the measured number falls inside the stated range.
By their numbers in this assay, from the lowest: compounds 3, 2 and 4 (each within the scatter of the next, the first and the last beyond it); then compound 1.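

In this assay, the ring on this sulfur is not interchangeable: 1-(pyridin-2-yl)ethyl in place of 1-phenylethyl gives a 2.6-fold higher number from compound 3 to compound 4 (0.42 log units; beyond the scatter), a modest step but beyond the scatter. Even so, the pyridine-bearing group retains a large advantage over 1-methyl-1-phenylethyl, with a 16-fold lower number from compound 1 to compound 4 (1.19 log units; beyond the scatter). Nothing available explains either step.

Compound 3 has a defined stereocentre and compound 4 has none, so the effect of the ring swap remains unseparated from that difference. Also open, as far as these compounds go, is how a 1-(pyridin-3-yl)ethyl group, or an amine on the ring, would compare.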